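Hydroxymethyl Added to the Methylamino Side Chain

The source may hold more compounds than are shown below. What is called first, only, known or untested is meant among the compounds shown, and "the series" means these compounds.

In a functional assay (Homo sapiens) for inhibition of Nucleic Acid, tested at 100 uM (a lower number here means less inhibition, a higher number more inhibition at the concentration tested (going by the name of the read-out)), compound 2 `CNc1[nH]ccc2ncnc1-2` gives 18%, the largest of the three numbers recorded. Compound 1 `c1ccc(Nc2[nH]ccc3ncnc2-3)cc1` gives 12%, which sits within the scatter of compound 2, while compound 3 `CC1OC(n2cnc3c(N)nccc32)CC1O` gives 3%, a gap that lies beyond the scatter. No pair among these three differs in a single place, so no measured step guides the next change.

Compound 4 `OCCNc1[nH]ccc2ncnc1-2` differs from compound 2 by hydroxymethyl in place of hydrogen on a saturated chain carbon bound to a nitrogen on an aromatic ring. Going by the values given here, with no comparable step on record, the expected change from compound 2 to compound 4 is none beyond the scatter, an expected step of no change at the digits printed from compound 2 to compound 4 (within the scatter). For compound 4 the estimated result in this assay is 18%, expected to fall between 5% and 32%.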

Compound 4, a percentage reported as inhibition, at one concentration (the size of the read-out at that concentration, not a potency): 3%
Estimate against measurement, compound 4: 15 percentage points above; the whole stated range lies above it.
By their numbers in this assay, from the lowest: compounds 3, 4, 1 and 2 (each within the scatter of the next, the first and the last beyond it).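

In this assay, going by these compounds alone, the first single-place change, hydroxymethyl in place of hydrogen on a saturated chain carbon bound to a nitrogen on an aromatic ring, gives a number 15 percentage points lower from compound 2 to compound 4 (beyond the scatter). This shows that the read-out responds to a change at this position, and that this particular extension of the methylamino side chain does not preserve the number seen for compound 2. Nothing available accounts for this drop.

On these data alone, it remains open whether the terminal hydroxyl or the longer chain drives the step. An ethyl, 2-methoxyethyl or 2-aminoethyl group in place of 2-hydroxyethyl would help separate the two.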